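The source may report more compounds than this note shows. Statements on the series, on what has been measured and on what is new or still open speak of the compounds shown alone.

Of the compounds shown here, three sharing one core have been measured in an assay on HEK293 cells for positive allosteric modulation of metabotropic glutamate receptor 2 (Rattus norvegicus), read by thallium flux, with a stated time of 2.5 min; a lower number here means that less compound is needed, a higher number that more compound is needed for the effect. Compound 1 `Cc1c(OCCCCOc2ccc(C(=O)O)cc2Cl)ccc(C(=O)CC(C)C)c1O` gives 96 nM. Compound 2 `Cc1c(OCCCCOc2cccc(C(=O)O)c2)ccc(C(=O)CC(C)C)c1O` gives 222 nM, and compound 3 `Cc1c(OCCCCOc2ccc(C(=O)O)c(Cl)c2)ccc(C(=O)CC(C)C)c1O` gives 151 nM. Compound 3 therefore sits second highest of the three numbers; its nearest neighbour is compound 2 and its furthest is compound 1, and both gaps lie within the scatter.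

Compound 4 `Cc1c(OCCCCOc2ccccc2C(=O)O)ccc(C(=O)CC(C)C)c1O` differs from compound 3 by one change: 2-carboxyphenyl in place of 4-carboxy-3-chlorophenyl on an oxygen on a saturated carbon. Two earlier steps moved the carboxylic acid around the same ring or removed the chlorine. The step of a 2.3-fold higher number from compound 1 to compound 2 (0.36 log units; beyond the scatter) was modest but beyond the scatter, while the step of a 1.5-fold lower number from compound 2 to compound 3 (0.17 log units; within the scatter) and the step of a 1.6-fold higher number from compound 1 to compound 3 (0.20 log units; within the scatter) stayed within it. Shifting the acid once more, now with the chlorine also gone, has no direct precedent here, so the expectation is a step in this assay of at most modest size, more likely toward a higher number than a lower one, and possibly none beyond the scatter.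

For compound 4 the expected step is a 2.0-fold higher number from compound 3 to compound 4 (0.30 log units; within the scatter). Compound 4 is thus estimated at 300 nM, in a range from 120 nM to 900 nM.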

Compound 4, half-maximal effective concentration: 415 nM
Beside the measured number, compound 4's estimate is 1.4-fold (0.14 log units) below it; measured number inside the range.
By their numbers in this assay, from the lowest: compounds 1, 3, 2 and 4 (each within the scatter of the next, the first and the last beyond it).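

In this assay, 2-carboxyphenyl on this oxygen is the only group shown whose steps from both chlorine-bearing compounds lie beyond the scatter, with a 2.7-fold higher number from compound 3 to compound 4 (0.44 log units; beyond the scatter) and a 4.3-fold higher number from compound 1 to compound 4 (0.64 log units; beyond the scatter) as the two results. Against the chlorine-free 3-carboxyphenyl of compound 2, the same group gives a 1.9-fold higher number from compound 2 to compound 4 (0.27 log units; within the scatter), so relocating the acid without any change in chlorine shows no shift beyond the scatter, while the two larger steps combine relocation of the acid with loss of the chlorine. Nothing available here explains these differences.

Open, going by these compounds, is how a 2-carboxyphenyl carrying a chlorine would read in this assay, which would help separate the two parts of this change. Every compound shown carries a carboxylic acid, so the effect of a tetrazole or an amide in its place, or of a longer chain leading to that ring, also remains unknown.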